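This account rests on a few compounds, and the source may have more. Where it says the series, first, only, none or still open, it means among the compounds named here.

Working notes on the series, read in an ADME assay on MDBK cells (Bos taurus) for cytotoxicity; on this read-out higher numbers stand for lower toxicity in this test and lower numbers for higher toxicity in this test. Compound 1 (`Fc1ccccc1Cn1ccc2nc(-c3ccccc3)nc-2c1`) gives > 100000 nM, which is a limit of the assay. As far as these compounds go, compound 2 (`N#Cc1cccc(Cn2ccc3nc(-c4ccccc4)nc-3c2)c1`) gives > 100000 nM, again a limit and not a number, so its true position is unknown. Compound 3 (`Clc1ccc(Cn2ccc3nc(-c4ccccc4)nc-3c2)cc1Cl`) has 3,4-dichlorophenyl in place of 3-cyanophenyl on a saturated chain carbon bound to an aromatic nitrogen. Within the data shown here, the only measured step at this place is a step that the two limits leave unreadable from compound 1 to compound 2, so it gives no size to carry over. Compound 1 and compound 2 both sit at the limit of > 100000 nM in this assay, at which 2 of the 2 values shown sit, and no step beyond the scatter is therefore expected, although this rests on only those two compounds. The expected step is an at least 1.1-fold lower number from compound 2 to compound 3 (0.04 log units; that floor lies within the scatter). The estimate for compound 3 is 90000 nM, with an expected range of 30000 nM to 100000 nM.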

Compound 3, half-maximal cytotoxic concentration: 71000 nM
Compound 3: middle estimate off by 1.3-fold (0.10 log units), on the high side; low and high end bracket the measured number.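

In this assay, among these compounds, compound 3 gives the first value of the series that is a number and not a limit, so 3,4-dichlorophenyl at this place brings the read-out within the measurable range. The change reads as an at least 1.4-fold lower number from compound 2 to compound 3 (0.14 log units; that floor lies within the scatter), and as an at least 1.4-fold lower number from compound 1 to compound 3 (0.14 log units; that floor lies within the scatter). Compound 1 and compound 2 remain limits and not numbers, so the true size of either step stays unread: the limit of > 100000 nM in this assay, at which 2 of the 3 values shown sit.

As far as these compounds go, whether the number for compound 3 depends on both chlorines of the 3,4-dichlorophenyl or on only one of them stays open. Also open, from the compounds shown here alone, is whether an amine, a carboxylic acid or a longer chain at this place would give a number or stay at the limit.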